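Dropping a methoxy from the chalcone aryl ring

The compounds below may be only part of what the source reports. "The series", "measured", "known", "first", "only" and "open" are said of these compounds alone.

Measured in a functional assay on Huh-7 cells (Homo sapiens) for cytotoxicity, with a stated time of 48 h; a lower number here means a stronger inhibitor, a higher number a weaker inhibitor:
- compound 1 `COc1cccc(/C=C/C(=O)c2c(OC)cc(OC)cc2OC)c1` gives 8900 nM
- compound 2 `COc1cc(OC)c(C(=O)/C=C/c2ccc(Br)cc2)c(OC)c1` gives 13900 nM
- compound 3 `COc1cc(O)c(C(=O)/C=C/c2ccccc2SC)c(OC)c1` gives 16600 nM

Compound 1 has the lowest number of the three, but both others lie within the usual scatter of it, so no order among them can be read. Compound 4 `COc1cc(OC)c(C(=O)/C=C/c2ccccc2)c(OC)c1` differs from compound 1 by hydrogen in place of methoxy on an aromatic carbon, or, cut one bond further out, 3-methoxyphenyl to phenyl. Going by the values given here, the one measured step that touches this ring, a 1.6-fold higher number from compound 1 to compound 2 (0.19 log units; within the scatter), swapped the whole aryl substituent and stayed within the scatter. Compound 3 differs in several places, so only its value can be compared. The change to compound 4 is therefore expected to leave this assay essentially unchanged, a 1.2-fold higher number from compound 1 to compound 4 (0.09 log units; within the scatter). Compound 4 is estimated at 11000 nM, with a range from 5000 nM to 25000 nM.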

Compound 4, half-maximal inhibitory concentration: 15500 nM
Estimate against measurement, compound 4: 1.4-fold (0.15 log units) below; low and high end bracket the measured number.
By their numbers in this assay, from the lowest: compounds 1, 2, 4 and 3 (each within the scatter of the next).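

Taking the methoxy off altogether gives a 1.7-fold higher number from compound 1 to compound 4 (0.24 log units; within the scatter) in this assay, so this group makes no difference that can be read here. Replacing bromo with hydrogen gives a 1.1-fold higher number from compound 2 to compound 4 (0.05 log units; within the scatter), so the unsubstituted phenyl of compound 4 also cannot be told apart from the 4-bromophenyl of compound 2. No measurement is available to explain these results. On these data alone, whether an amine or a carboxylic acid on this ring would move the number beyond the scatter remains open, as does the effect of a longer chain in place of the methoxy.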